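The source may report more compounds than this note shows. Statements on the series, on what has been measured and on what is new or still open speak of the compounds shown alone.

Measured compounds:
compound 1, `O=C(Nc1cccc(Cl)c1)c1cc(C(F)(F)F)ccc1OCc1ccccc1`, with 25.1 nM
compound 2, `CN1CCC(c2ccc(OCc3ccccc3)c(C(=O)Nc3ccnnc3)c2)CC1`, with 20 nM

Both compounds were tested in an assay on Sf9 cells for inhibition of Leucine-rich repeat serine/threonine-protein kinase 2 (Homo sapiens), read by TR-FRET, with stated times of 30 min and 2 h; a higher number here means a weaker inhibitor, a lower number a stronger inhibitor. Compound 1 gives 25.1 nM, while compound 2 gives 20 nM. Compound 2 carries the lower of the two numbers, but its gap to compound 1 lies within the usual scatter of repeated measurements, so the two compounds cannot be separated on these data. Compound 3, `N#CC1CCN(c2ccc(OCc3ccccc3)c(C(=O)Nc3ccnnc3)c2)CC1`, has not yet been measured. It differs from compound 2 in one place: 4-cyanopiperidin-1-yl in place of 1-methylpiperidin-4-yl on an aromatic carbon. For the measured compounds named here, no pair of measured compounds differing in a single place is available, and compounds 1 and 2 differ from each other in several places at once, so this exchange has no precedent in the data. On that basis only a modest step is expected from compound 2 to compound 3, leaning toward a higher number, and plausibly still within the scatter, as expressed by the estimated step of a 2.0-fold higher number from compound 2 to compound 3 (0.30 log units; within the scatter). Compound 3 is expected to give about 40 nM in this assay, within a range of 10 nM to 160 nM.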

Compound 3, half-maximal inhibitory concentration: 10 nM
For compound 3 the middle estimate is 4.0-fold (0.60 log units) above the measured one, within the range that was stated.
By their numbers in this assay, from the lowest: compounds 3, 2 and 1 (each within the scatter of the next, the first and the last beyond it).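

In this assay the exchange of 1-methylpiperidin-4-yl for 4-cyanopiperidin-1-yl gives a 2.0-fold lower number from compound 2 to compound 3 (0.30 log units; within the scatter) and so leaves the two compounds inseparable. For the compounds shown here, this is the first direct reading at this position, meta to a (pyridazin-4-yl)carbamoyl group and para to a benzyloxy group: it carries a piperidine ring joined through its nitrogen and bearing a nitrile as well as one joined through carbon with a methyl on its nitrogen, with no difference that can be told apart, even though the entering group adds a triple bond outside aromatic rings and a further hydrogen-bond acceptor. No measurement of any property of these groups bears on this result.

As far as these compounds go, the step alters the ring's point of attachment and its substituent together, so the share of each stays open, and a plain piperidin-1-yl group would be needed to part them. Also open, from the compounds shown here alone, is how this position responds to more distant groups, such as a morpholin-4-yl ring, a primary amine or a carboxylic acid, and whether any such exchange would move the number beyond the scatter.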